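From methyl to methoxy: estimating compound 4

This account rests on a few compounds, and the source may have more. Where it says the series, first, only, none or still open, it means among the compounds named here.

Measured so far in a functional assay on HCT-116 cells (Homo sapiens) for inhibition, read by MTT assay, with a stated time of 48 h; on this read-out lower numbers stand for stronger inhibition and higher numbers for weaker inhibition
- Compound 1 `COc1ccc(/C=C2\SC(=O)N(CCNC(=O)Nc3c(C)n(C)n(-c4ccccc4)c3=O)C2=O)cc1` gives 3160 nM
- Compound 2 `Cc1c(NC(=O)NCCN2C(=O)S/C(=C\c3ccc([N+](=O)[O-])cc3)C2=O)c(=O)n(-c2ccccc2)n1C` gives 44800 nM
- Compound 3 `Cc1ccc(/C=C2\SC(=O)N(CC(=O)Nc3c(C)n(C)n(-c4ccccc4)c3=O)C2=O)cc1` gives 47700 nM

Compound 3 at 47700 nM stands level with compound 2 within the usual scatter, and both lie far above compound 1. Compound 4 `COc1ccc(/C=C2\SC(=O)N(CC(=O)Nc3c(C)n(C)n(-c4ccccc4)c3=O)C2=O)cc1` has methoxy in place of methyl on an aromatic carbon, a swap of 4-methylphenyl to 4-methoxyphenyl, counted as methoxy in place of methyl on an aromatic carbon in full. Among the compounds with values here, no measured step makes this exact change. The closest evidence is a 14-fold higher number from compound 1 to compound 2 (1.15 log units; beyond the scatter) for nitro in place of methoxy at that same aromatic carbon, so a change there can matter greatly. Within the data shown here, compound 1, the only measured compound with methoxy, shows 3160 nM but differs from compound 4 in its linking chain, which makes it a loose guide. A modest move towards a lower number is therefore expected in this assay, and the estimated size is a 2.4-fold lower number from compound 3 to compound 4 (0.38 log units; beyond the scatter) for this change. Compound 4 is estimated at 20000 nM with an expected range from 5000 nM to 70000 nM in this assay.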

Compound 4, half-maximal inhibitory concentration: 70300 nM
For compound 4 the middle estimate is 3.5-fold (0.55 log units) below the measured one; measured number above the stated range.
By their numbers in this assay, from the lowest: compound 1; then compounds 2, 3 and 4 (each within the scatter of the next).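

In this assay the step of a 1.5-fold higher number from compound 3 to compound 4 (0.17 log units; within the scatter), for methoxy in place of methyl, lies within the scatter, so with this linking chain the swap makes no readable difference. The earlier compounds shown here showed that a change at this aromatic carbon can matter greatly, whereas this pair shows that not every change there does, and that methoxy alone does not guarantee a low number, since compound 4 carries it and stays far from compound 1 at 3160 nM, which has a different linking chain. Nothing measured here explains why this swap leaves the number so flat.

From the compounds shown here alone, what an amine or a chlorine atom would do at this carbon remains open. Going by these compounds, it is also open whether the methyl group would behave the same way on the linking chain of compound 1.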